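This account rests on a few compounds, and the source may have more. Where it says the series, first, only, none or still open, it means among the compounds named here.

Compound 2 `Cc1cc(C(=O)Nc2cc(Cl)cc(Cl)c2)nn1-c1cccc(C(F)(F)F)c1` is the best-placed compound among the numbers seen so far: in an assay on HEK293 cells for binding affinity to Neuropeptide Y receptor type 5 (Homo sapiens), read by radioligand binding (a lower number here means a stronger inhibitor, a higher number a weaker inhibitor), compound 2 gives 150 nM. Compound 1 `Cc1cc(C(=O)Nc2ccc(F)cc2)nn1-c1cccc(C(F)(F)F)c1` gives 800 nM, and the step of a 5.3-fold lower number from compound 1 to compound 2 (0.73 log units; beyond the scatter). Compound 3 `Cc1cc(C(=O)Nc2cc(Cl)cc(Cl)c2)nn1-c1ccc(C(F)(F)F)cc1` reaches only (the limit of > 1000 nM in this assay, at which 1 of the 3 values shown sits), so in this assay compound 3 gives > 1000 nM as a limit and not a number. Compound 4 `COc1cccc(-n2nc(C(=O)Nc3cc(Cl)cc(Cl)c3)cc2C)c1` differs from compound 2 by methoxy in place of trifluoromethyl on an aromatic carbon. For the measured compounds named here, no measured step changes that group, so the one step seen, which alters the amide-side ring, gives no direct guide, and the expectation rests only on compound 2 and on uncertainty. The estimated step of a 2.7-fold higher number from compound 2 to compound 4 (0.43 log units; beyond the scatter) points toward a weaker compound, and compound 4 is expected to give about 400 nM, in the range 100 nM to 2000 nM.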

Compound 4, half-maximal inhibitory concentration: > 1000 nM
Compound 4 ended at the assay's limit (the forecaster's own chance of this, stated with the estimate: 25%); middle value at least 2.5-fold (0.39 log units) from the limit.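

Replacing trifluoromethyl with methoxy on this aromatic carbon gives an at least 6.6-fold higher number from compound 2 to compound 4 (0.82 log units; beyond the scatter) in this assay. For the compounds shown here, this is the first measured step at this position, and it shows that the group held here matters, not only the amide-side ring. Going by these compounds, compound 4 gives > 1000 nM, which is a limit of the assay and not a number, so the full size of the step remains unknown.

On these data alone, whether any other group on this carbon, such as a nitrile or an amine, would match trifluoromethyl remains open. So does whether any group here could give a lower number than compound 2 gives.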